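Ortho substitution versus ring fusion on the aryl ether

The compounds below may be only part of what the source reports. "The series", "measured", "known", "first", "only" and "open" are said of these compounds alone.

Compound 3 `c1cc2c(c(OC3CCN(c4ccc(-n5ccnc5)nn4)CC3)c1)CCC2` gives 10 nM in an assay on microsomes from liver for inhibition of acyl-CoA desaturase 1 (Rattus norvegicus) (a higher number here means a weaker inhibitor, a lower number a stronger inhibitor), the lowest number among the three measured compounds. Compound 1 `Cc1ccccc1OC1CCN(c2ccc(-n3ccnc3)nn2)CC1` gives 39 nM in this assay, and compound 2 `Cc1ccc(OC2CCN(c3ccc(-n4ccnc4)nn3)CC2)cc1` gives 527 nM. The steps show a 3.9-fold lower number from compound 1 to compound 3 (0.59 log units; beyond the scatter), a 53-fold lower number from compound 2 to compound 3 (1.72 log units; beyond the scatter) and a 14-fold higher number from compound 1 to compound 2 (1.13 log units; beyond the scatter).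

Compound 4 `CCc1ccccc1OC1CCN(c2ccc(-n3ccnc3)nn2)CC1` differs from compound 3 by 2-ethylphenyl in place of 2,3-dihydro-1H-inden-4-yl on an oxygen on a saturated carbon. This change bears most closely on the step from compound 1 to compound 3, which opened the fused five-membered ring out of a 2-methylphenyl; compound 4 keeps an ortho-placed chain one carbon longer than that of compound 1, so it sits between compound 1 and compound 3 in the structures measured. In this assay compound 1 gives 39 nM and compound 3 gives 10 nM. The number for compound 4 is therefore expected to lie between these two values. For compound 4 the expected step is a 2.2-fold higher number from compound 3 to compound 4 (0.34 log units; beyond the scatter), modest and close to the scatter. The estimate for compound 4 is 22 nM, range 8 nM to 65 nM.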

Compound 4, half-maximal inhibitory concentration: 4 nM
Compound 4: middle estimate off by 5.5-fold (0.74 log units), on the high side; the whole stated range lies above it.
By their numbers in this assay, from the lowest: compound 4; then compound 3; then compound 1; then compound 2.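

Opening the ring does not cost binding here: 2-ethylphenyl in place of 2,3-dihydro-1H-inden-4-yl gives a 2.5-fold lower number from compound 3 to compound 4 (0.40 log units; beyond the scatter) in this assay, so on this oxygen on a saturated carbon the closed ring is not needed for a low number. Methyl in place of hydrogen on the saturated chain carbon bound to an aromatic carbon gives a 9.8-fold lower number from compound 1 to compound 4 (0.99 log units; beyond the scatter), so extending the methyl of compound 1 to an ethyl matters at this position, and 2-ethylphenyl in place of 4-methylphenyl gives a 130-fold lower number from compound 2 to compound 4 (2.12 log units; beyond the scatter). Nothing shown gives a reason for these steps.

Going by these compounds, it remains open whether a longer chain such as propyl, or a branched isopropyl or cyclopropyl group, at this place lowers the number further or reverses the trend. On these data alone, the effect of a methoxy group or a chlorine atom there is also open.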